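From acetyl to phenylsulfonyl on a shared core

A few compounds are considered here, and "the series" means these few. Any claim that something is new, unique, unknown or untested is made for them only; others in the source may bear on it.

In a functional assay on HepG2 cells (Homo sapiens) for cytotoxicity, read by sulforhodamine B assay, with a stated time of 24 h (on this read-out higher numbers stand for weaker inhibition and lower numbers for stronger inhibition), compound 3 (`CC(=O)N/N=C1\C(=O)Nc2ccc(S(=O)(=O)N3CCOCC3)cc21`) gives 27500 nM. Compound 2 (`COc1ccc(-c2c(C#N)c(N)n(/N=C3\C(=O)Nc4ccc(S(=O)(=O)N5CCOCC5)cc43)c(=O)c2C#N)cc1`) gives 15000 nM, which lies within the usual scatter of compound 3. Compound 1 (`N=c1oc2ccccc2cc1C(=O)N/N=C1\C(=O)Nc2ccc(S(=O)(=O)N3CCOCC3)cc21`) gives 7820 nM, a lower number than compound 3 by more than that scatter.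

Compound 4 (`O=C1Nc2ccc(S(=O)(=O)N3CCOCC3)cc2/C1=N/NS(=O)(=O)c1ccccc1`) has phenylsulfonyl in place of acetyl on an amine nitrogen.

Among the compounds with values here, one measured step bears on this change: a 3.5-fold higher number from compound 1 to compound 3 (0.55 log units; beyond the scatter). In it, a large group containing aromatic rings, sitting on a carbonyl carbon, gives way to one carbon atom. Read in reverse, that step pairs the larger aromatic group with the lower number. Compound 4 also gains an aromatic ring, but the group that carries it is a different one, so this single step is only a weak guide.

A small move toward a lower number in this assay is expected, namely a 2.1-fold lower number from compound 3 to compound 4 (0.33 log units; beyond the scatter). Compound 4 is estimated at 13000 nM, with an expected range of 5000 nM to 32000 nM.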

Compound 4, half-maximal inhibitory concentration: 23900 nM
Compound 4: middle estimate off by 1.8-fold (0.26 log units), on the low side, and the stated range covers the measured number.
By their numbers in this assay, from the lowest: compounds 1, 2, 4 and 3 (each within the scatter of the next, the first and the last beyond it).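

In this assay, phenylsulfonyl in place of acetyl on the amine nitrogen gives a 1.2-fold lower number from compound 3 to compound 4 (0.06 log units; within the scatter), so the two groups cannot be told apart at this place, even though phenylsulfonyl brings an aromatic ring. Within the data shown here, the step with a 3.5-fold higher number from compound 1 to compound 3 (0.55 log units; beyond the scatter), which lies beyond the scatter and concerns a group on a carbonyl carbon, therefore finds no counterpart in this change. No measurement at hand offers an explanation for the difference between these two steps.

Still open, from the compounds shown here alone, is whether a benzoyl group, which keeps the aromatic ring but replaces the sulfonyl with a carbonyl, would give a similar number. Also open, going by these compounds, is how methylsulfonyl, which keeps the sulfonyl without the ring, or a phenylsulfonyl carrying a methoxy group would read here.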